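The source may report more compounds than this note shows. Statements on the series, on what has been measured and on what is new or still open speak of the compounds shown alone.

Working notes on the series. Compound 1 `CCCOCN1c2ccccc2C(=O)NS1(=O)=O` is the reference member; in a functional assay on CCRF-CEM cells (Homo sapiens) for cytotoxicity (on this read-out higher numbers stand for lower toxicity in this test and lower numbers for higher toxicity in this test), compound 1 reaches only the assay limit, > 200 ug/mL. Compound 3 `O=C1NS(=O)(=O)N(COCc2ccccc2)c2ccccc21` differs from compound 1 by phenyl in place of ethyl on a saturated chain carbon bound to an oxygen on a saturated carbon. In this assay compound 3 likewise returns only a limit, > 200 ug/mL. The step that the two limits leave unreadable from compound 1 to compound 3 is therefore not readable in size, both of its ends standing at the limit of > 200 ug/mL in this assay, at which 2 of the 3 values shown sit. Compound 2 `O=C1c2ccccc2N(COCCO)S(=O)(=O)N1Cc1ccccc1` carries an additional benzyl on the ring nitrogen next to the carbonyl and the 2-hydroxyethyl chain; in this assay compound 2 gives 89 ug/mL, a number rather than a limit. Among the measured compounds shown here, no single-place step links compound 2 to the pair under study, so it only shows that a measurable value is reachable.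

Compound 4 `O=C1NS(=O)(=O)N(COCCO)c2ccccc21` differs from compound 3 by hydroxymethyl in place of phenyl on a saturated chain carbon bound to an oxygen on a saturated carbon. For the measured compounds named here, the one measured step that bears on this change, a step that the two limits leave unreadable from compound 1 to compound 3, is unreadable, and its two ends sit at the limit of > 200 ug/mL in this assay, at which 2 of the 3 values shown sit, so no direction can be drawn from it. The expected step of a number no higher from compound 3 to compound 4 (the limit leaves the size open) is nothing beyond the scatter, with a fair chance that compound 4 again comes back as a limit. Compound 4 is estimated at 200 ug/mL, with a range from 100 ug/mL to 400 ug/mL.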

Compound 4, half-maximal cytotoxic concentration: 15 ug/mL
For compound 4 the middle estimate is 13-fold (1.12 log units) above the measured one, and the stated range ends above it.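

At the place on a saturated chain carbon bound to an oxygen on a saturated carbon, the series now has a readable direction in this assay: hydroxymethyl in place of phenyl gives an at least 13-fold lower number from compound 3 to compound 4 (1.12 log units; beyond the scatter), and hydroxy in place of methyl, two bonds along the chain from an oxygen on a saturated carbon, gives an at least 13-fold lower number from compound 1 to compound 4 (1.12 log units; beyond the scatter). Both sizes are only bounds, as one end of each step is a limit: the limit of > 200 ug/mL in this assay, at which 2 of the 4 values shown sit. With the 2-hydroxyethyl chain kept, hydrogen in place of benzyl on an amide-type nitrogen in a ring gives a 5.9-fold lower number from compound 2 to compound 4 (0.77 log units; beyond the scatter), so a second place also moves the number.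

As far as these compounds go, whether an amine or a carboxylic acid at the end of the chain, or a longer chain carrying the hydroxy, would give a similar number stays open. Also open, from the compounds shown here alone, is whether benzyl on that nitrogen would shift the number on the chains of compound 1 and compound 3.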